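Series notes: pyridinylmethoxy in place of carboxy on the core

This account rests on a few compounds, and the source may have more. Where it says the series, first, only, none or still open, it means among the compounds named here.

Among the compounds with values here, compound 2 `CCCc1cc(C(=O)O)cc(=O)n1Cc1ccc(-c2ccccc2-c2nn[nH]n2)cc1` gives 0.078 mg/kg in a functional assay on the whole organism with Rattus norvegicus as the target (on this read-out lower numbers stand for an effect already at smaller amounts and higher numbers for an effect only at larger amounts of compound), the lowest of the two numbers so far; the nearest is compound 1 `CCCc1cccc(=O)n1Cc1ccc(-c2ccccc2-c2nn[nH]n2)cc1`, which gives 1.1 mg/kg in this assay. Within the data shown here, the one measured step is a 14-fold lower number from compound 1 to compound 2 (1.15 log units; beyond the scatter), a large gain tied to the carboxy group alone. Compound 3 `CCCc1cc(OCc2cccnc2)cc(=O)n1Cc1ccc(-c2ccccc2-c2nn[nH]n2)cc1` is not yet measured; it differs from compound 2 by (pyridin-3-yl)methoxy in place of carboxy on an aromatic carbon. Among the measured compounds shown here, the only step that bears on this change is the one from compound 1 to compound 2, and it runs the other way: the carboxy that is now removed is exactly the group whose arrival brought the large drop. Nothing measured tells what (pyridin-3-yl)methoxy contributes at that position, so the expectation rests on the loss of the carboxy and treats the entering group as unknown. A step toward higher numbers beyond the scatter is therefore expected, but smaller than a full return to compound 1, giving an expected step of a 6.4-fold higher number from compound 2 to compound 3 (0.81 log units; beyond the scatter). Compound 3 is thus estimated at 0.5 mg/kg, in a range from 0.1 mg/kg to 2.5 mg/kg.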

Compound 3, dose for 50% inhibition: 0.72 mg/kg
The estimate for compound 3 lay 1.4-fold (0.16 log units) below the measured number, within the range that was stated.
By their numbers in this assay, from the lowest: compound 2; then compounds 3 and 1 (each within the scatter of the next).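

In this assay, (pyridin-3-yl)methoxy in place of carboxy, on the aromatic carbon opposite the ring nitrogen, gives a 9.2-fold higher number from compound 2 to compound 3 (0.97 log units; beyond the scatter) and so does not keep the low number seen with carboxy, even though the entering group has more heavy atoms and adds a six-membered aromatic ring. Set against hydrogen at the same carbon, the same group gives a 1.5-fold lower number from compound 1 to compound 3 (0.18 log units; within the scatter) and cannot be told apart from hydrogen in this read-out, so the position accepts this larger group without a step beyond the scatter, and of the two groups tried there, only carboxy goes with a step beyond the scatter from hydrogen. The data at hand offer no measurement that would explain why carboxy and (pyridin-3-yl)methoxy part in this way.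

Still open, on these data alone, is whether the low number of compound 2 belongs to the carboxylic acid itself or would also appear with a methyl ester or a primary amide on this carbon. Also open, as far as these compounds go, is whether a plain methoxy, a benzyloxy or a (pyridin-4-yl)methoxy group would match (pyridin-3-yl)methoxy here or move the number in either direction.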